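The source may hold more compounds than are shown below. What is called first, only, known or untested is meant among the compounds shown, and "the series" means these compounds.

In a physicochemical assay for lipophilicity, using the shake flask method (a lower number here means a more polar compound, a higher number a more lipophilic compound), compound 2 `N/N=C/c1c(N)ncnc1Oc1ccc(NC(=O)C2(C(=O)Nc3ccc(F)cc3)CC2)cc1F` gives 2.25, the lowest of the two numbers, while compound 1 `C=CCO/N=C/c1c(N)ncnc1Oc1ccc(NC(=O)C2(C(=O)Nc3ccc(F)cc3)CC2)cc1F` gives 3.65. Among the compounds with values here, the only measured step, a number 1.40 log units lower from compound 1 to compound 2 (beyond the scatter), is the one that bears on the next change, although it moved a different group at the same place. Compound 3 `Nc1ncnc(Oc2ccc(NC(=O)C3(C(=O)Nc4ccc(F)cc4)CC3)cc2F)c1/C=N/O` differs from compound 2 by hydroxy in place of amino on a double-bonded nitrogen. Since one heavy atom is exchanged for another without any change in the counted donors and acceptors, no step beyond the scatter is expected in this assay. For compound 3 the estimated value is 2.5, within a range of 2.05 to 2.95. This estimate means an expected a number 0.25 log units higher from compound 2 to compound 3 (within the scatter).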

Compound 3, partition coefficient: 2.62
Beside the measured number, compound 3's estimate is 0.12 log units below it, and the stated range covers the measured number.
By their numbers in this assay, from the lowest: compound 2; then compound 3; then compound 1.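

In this assay hydroxy in place of amino on the double-bonded nitrogen gives a number 0.37 log units higher from compound 2 to compound 3 (beyond the scatter) even though the two groups count the same donors and acceptors, so this one-atom exchange does register here. Hydrogen in place of allyl on the oxygen gives a number 1.03 log units lower from compound 1 to compound 3 (beyond the scatter) and so is the larger of the two steps at this place. Nothing measured here gives a cause for either step.

From the compounds shown here alone, how a methyl or a longer chain on that oxygen would fall relative to compound 3 and compound 1 stays open. So does the effect of a carboxylic acid carried on that oxygen.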